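The source may hold more compounds than are shown below. What is called first, only, known or untested is meant among the compounds shown, and "the series" means these compounds.

Measured so far:
Compound 1 `O=[N+]([O-])c1ccc(Cn2cc(COc3ccc(Cl)cc3)nn2)cc1` — in an ADME assay on A549 cells (Homo sapiens) for inhibition, read by MTT assay, with a stated time of 48 h (a higher number here means a weaker inhibitor of growth, a lower number a stronger inhibitor of growth), compound 1 reaches only the limit > 100 ug/mL.
Compound 2 `Clc1ccc(OCc2cn(Cc3cccc(Cl)c3)nn2)cc1` — in this assay compound 2 likewise reaches only the limit > 100 ug/mL.

Compound 2 stands, then, not at a number but at a limit of this assay, and the same is true of compound 1: both values sit at the limit of > 100 ug/mL in this assay, at which 2 of the 2 values shown sit, so no step between measured compounds can be read, and nothing separates the two on what is shown.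

Compound 3 `Clc1ccc(OCc2cn(Cc3ccc(Br)cc3)nn2)cc1` differs from compound 2 by 4-bromophenyl in place of 3-chlorophenyl on a saturated chain carbon bound to an aromatic nitrogen. Among the measured compounds shown here, with both measured values at the limit, there is no measured step to guide the size of the change; the expectation for the step into this assay is none beyond the scatter. The expected step is a step that the limit leaves unreadable from compound 2 to compound 3. Compound 3 is expected to give 150 ug/mL, within a range from 60 ug/mL to 400 ug/mL, most likely again as a limit.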

Compound 3, concentration for 50% growth inhibition: > 100 ug/mL
Compound 3 ended at the assay's limit (the forecaster's own chance of this, stated with the estimate: 80%); the middle value does not contradict the limit.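

Among the compounds shown here, no step from compound 1 or compound 2 to compound 3 can be read, because all three compounds stand at the same limit of this assay: the limit of > 100 ug/mL in this assay, at which 3 of the 3 values shown sit.

The compounds shown leave open whether any change on the shared core brings a readable value in this assay.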